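The source may report more compounds than this note shows. Statements on the series, on what has been measured and on what is new or still open speak of the compounds shown alone.

In an in vivo ADME assay on the whole organism (plasma) for pharmacokinetics, with Rattus norvegicus as the target, at a dose of 50 mg/kg by the oral route (on this read-out higher numbers stand for higher exposure at the dose given and lower numbers for lower exposure), compound 2 `Cc1cc(C)c(NC(=O)c2sccc2S(=O)(=O)Nc2onc(C)c2Cl)c(C(=O)c2ccccc2)c1` gives 63100 nM and compound 1 `Cc1cc(C)c(NC(=O)c2sccc2S(=O)(=O)Nc2onc(C)c2Cl)c(C(=O)C2CC2)c1` gives 108000 nM within the scatter of each other. Compound 3 `C/C(=N\O)c1cc(C)cc(C)c1NC(=O)c1sccc1S(=O)(=O)Nc1onc(C)c1Cl` alters compound 2 at one place: a group of 4 heavy atoms (2 carbon, 1 nitrogen, 1 oxygen; no ring) in place of a group of 8 heavy atoms (7 carbon, 1 oxygen; one six-membered aromatic ring of carbon only), on an aromatic carbon ortho to a large group. Among the measured compounds shown here, the only measured step that bears on this is a 1.7-fold lower number from compound 1 to compound 2 (0.23 log units; within the scatter) and that step kept the carbonyl, so it guides the present change only loosely. In this assay the expected change is a 1.3-fold lower number from compound 2 to compound 3 (0.10 log units; within the scatter) and no step beyond the scatter is expected. For compound 3 the estimate is 50000 nM with an expected range from 15000 nM to 130000 nM for repeated measurements.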

Compound 3, maximal plasma concentration: 14300 nM
Compound 3: the middle estimate sits 3.5-fold (0.54 log units) above what was measured, and the stated range ends above it.
By their numbers in this assay, from the lowest: compound 3; then compounds 2 and 1 (each within the scatter of the next).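

In this assay, the aromatic carbon ortho to a large group responds to this change: the ringless group of 4 heavy atoms in place of benzoyl gives a 4.4-fold lower number from compound 2 to compound 3 (0.64 log units; beyond the scatter), whereas the cyclopropyl-to-phenyl exchange on the carbonyl stayed within the scatter. In place of the cyclopropyl carbonyl group, the same group gives a 7.6-fold lower number from compound 1 to compound 3 (0.88 log units; beyond the scatter). Nothing available accounts for these steps.

Going by these compounds, whether an acetyl group or an amine at this carbon would sit with compound 1 and compound 2 or with compound 3 remains open. The contributions of the carbonyl and of the ring therefore stay unseparated.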